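The compounds below may be only part of what the source reports. "The series", "measured", "known", "first", "only" and "open" are said of these compounds alone.

Measured compounds:
compound 1, `O=S(=O)(NCCNCc1ccc(-c2ccccc2)cc1)c1cc(C(F)(F)F)cc(C(F)(F)F)c1`, 2800 nM;
compound 2, `CN(CCCNS(=O)(=O)c1cc(C(F)(F)F)cc(C(F)(F)F)c1)Cc1ccccc1`, 30000 nM;
compound 3, `CC(C)(C)c1ccc(CNCCNS(=O)(=O)c2cc(C(F)(F)F)cc(C(F)(F)F)c2)cc1`, 14000 nM.

All three were tested in a functional assay on HPAC cells (Homo sapiens) for inhibition, read by MTT assay, with a stated time of 72 h; a lower number here means a stronger inhibitor of growth, a higher number a weaker inhibitor of growth. Compound 2 gives the highest number of the three: compound 3 stands nearest to it, with a lower value, and compound 1 is furthest, with a much lower value still. Among the measured compounds shown here, the only one-place step among the measured compounds, a 5.0-fold higher number from compound 1 to compound 3 (0.70 log units; beyond the scatter), concerns a change on the aromatic ring and does not bear directly on the change to compound 4. Compound 4, `COc1ccccc1CNCCCNS(=O)(=O)c1cc(C(F)(F)F)cc(C(F)(F)F)c1`, differs from compound 2 by (2-methoxybenzyl)amino in place of benzyl(methyl)amino on a saturated chain carbon, three bonds along the chain from a sulfonamide nitrogen. For the measured compounds named here, no measured pair isolates either the methoxy group or the removal of the methyl from the chain nitrogen, so the step can only be judged by comparison with compounds 1 and 3, both of which carry an unsubstituted chain nitrogen and give lower numbers than compound 2. On that basis the number for compound 4 is expected to move downward, a modest step, a 2.5-fold lower number from compound 2 to compound 4 (0.40 log units; beyond the scatter). The estimate for compound 4 is 12000 nM, within a range from 4000 nM to 35000 nM.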

Compound 4, concentration for 50% growth inhibition: 2400 nM
Beside the measured number, compound 4's estimate is 5.0-fold (0.70 log units) above it; measured number outside the range, below it.
By their numbers in this assay, from the lowest: compounds 4 and 1 (each within the scatter of the next); then compound 3; then compound 2.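

In this assay, the change on a saturated chain carbon, three bonds along the chain from a sulfonamide nitrogen, gives a 13-fold lower number from compound 2 to compound 4 (1.10 log units; beyond the scatter) as a large step. This shows that the growth inhibition of this series responds strongly to what this position carries: (2-methoxybenzyl)amino, with its hydrogen-bond donor on the chain nitrogen, gives a far stronger inhibitor than benzyl(methyl)amino, which has none. Nothing measured here accounts for the size of this step.

The step joins two changes, the loss of the methyl from the chain nitrogen and the arrival of the methoxy, and the compounds shown do not separate them. They also leave open how a hydroxyl or a chlorine in place of the methoxy would read in this assay.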